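The compounds below may be only part of what the source reports. "The series", "measured", "known", "first", "only" and "open" are said of these compounds alone.

Of the compounds shown here, two have been measured in a functional assay on CHO cells for agonist activity at metabotropic glutamate receptor 2 (Homo sapiens), read by scintillation counting and GTPgammaS binding, with a stated time of 30 min; on this read-out lower numbers stand for an effect already at smaller amounts and higher numbers for an effect only at larger amounts of compound. Compound 2 `COc1cccc(F)c1C1CCN(c2ccn3c(CC4CC4)nnc3c2Cl)CC1` gives 6 nM. Compound 1 `COc1ccc(F)cc1C1CCN(c2ccn3c(CC(F)(F)F)nnc3c2Cl)CC1` gives 10.5 nM, and these two values lie within the usual scatter of each other, so neither stands apart. Compound 3 `COc1cc(F)cc(F)c1C1CCN(c2ccn3c(CC4CC4)nnc3c2Cl)CC1` differs from compound 2 by fluoro in place of hydrogen on an aromatic carbon, a change that turns a 2-fluoro-6-methoxyphenyl group into a 2,4-difluoro-6-methoxyphenyl group. Going by the values given here, no measured pair shows this change, so its effect is unknown. A small step in either direction, or none beyond the scatter, is expected, as no change at the digits printed from compound 2 to compound 3 (within the scatter). Compound 3 is therefore estimated at 6 nM, between 2.5 nM and 15 nM.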

Compound 3, half-maximal effective concentration: 6.9 nM
Beside the measured number, compound 3's estimate is 1.2-fold (0.06 log units) below it, within the range that was stated.
By their numbers in this assay, from the lowest: compounds 2, 3 and 1 (each within the scatter of the next).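

In this assay, fluoro in place of hydrogen on this aromatic carbon, para to a large group, gives a 1.2-fold higher number from compound 2 to compound 3 (0.06 log units; within the scatter). So a 2,4-difluoro-6-methoxyphenyl group serves as well here as a 2-fluoro-6-methoxyphenyl group, at least with this core and side chain. Nothing measured here bears on the reason for this result. From the compounds shown here alone, it remains open whether a chlorine, a nitrile or a carboxylic acid on this same carbon would also stay within the scatter of compound 2.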